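The source may hold more compounds than are shown below. What is called first, only, known or untested is meant among the compounds shown, and "the series" means these compounds.

Of the compounds shown here, two have been measured so far. Compound 1, with the structure `O=C(NCc1ccc(CNS(=O)(=O)c2cccc(F)c2)cc1)c1cc2ccccn2n1`, and compound 2, with the structure `Cn1nccc1C(=O)NCc1ccc(CNS(=O)(=O)c2ccc3c(c2)CCO3)cc1`, were both tested in an assay on cells for inhibition of C-X-C chemokine receptor type 4 (Homo sapiens), with a stated time of 22 h, tested at 100 nM; on this read-out lower numbers stand for less inhibition and higher numbers for more inhibition at the one concentration tested (going by the name of the read-out). In this assay compound 1 gives 40%, and compound 2 gives 40%. Compound 2 therefore stands level with compound 1 at the digits shown; the two values lie within the usual scatter of the measurement, so no order between them can be read from these numbers.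

A third compound now comes in: compound 3, with the structure `O=C(NCc1ccc(CNS(=O)(=O)c2ccc3c(c2)CCO3)cc1)c1cc2ccccn2n1`, not yet measured in this assay. It differs from compound 2 in one place: a group of 9 heavy atoms (7 carbon, 2 nitrogen; one five-membered aromatic ring with 2 hetero atoms, one six-membered aromatic ring with 1 hetero atom) in place of a group of 6 heavy atoms (4 carbon, 2 nitrogen; one five-membered aromatic ring with 2 hetero atoms), on a carbonyl carbon.

Among the measured compounds shown here, no measured pair shows what such a change does here, so the expectation rests on the one value available. Because compound 2 gives 40%, the step from compound 2 to compound 3 is expected to be small, with no direction beyond the scatter, an estimated no change at the digits printed from compound 2 to compound 3 (within the scatter). For compound 3 the estimate is 40%, with an expected range from 20% to 60%.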

Compound 3, a percentage reported as inhibition, at one concentration (the size of the read-out at that concentration, not a potency): 40%
Compound 3: the middle estimate sits on the measured number at the digits printed; the measured number falls inside the stated range.
By their numbers in this assay, from the lowest: compounds 1, 2 and 3 (each within the scatter of the next).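

Replacing the 1-methyl-1H-pyrazol-5-yl group on the carbonyl carbon with a larger two-ring group gives no change at the digits printed from compound 2 to compound 3 (within the scatter) in this assay, so this read-out does not separate these two groups at this place. The same compound also gives the first view of a change on the sulfonyl sulfur: a ring group containing oxygen in place of a fluorine-bearing carbon ring gives no change at the digits printed from compound 1 to compound 3 (within the scatter) in this assay, so neither of the two single changes shown here separates from the scatter. No independent data bear on why these exchanges leave the read-out level.

The compounds shown leave open whether a group of a different kind on the carbonyl carbon, such as an amine or a carboxylic acid, or a longer chain on the sulfonyl sulfur, would move the result beyond the scatter. Because the read-out comes from a single concentration, they also leave open whether compounds that stand level here would still stand level across a range of concentrations.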